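The source may report more compounds than this note shows. Statements on the series, on what has been measured and on what is new or still open speak of the compounds shown alone.

Compound 3 `CC1CCN(c2c(S(=O)(=O)c3cccc(C#N)c3)cnc3cc(F)ccc23)CC1` sits with compound 2 near the top of the three values in an assay on isolated protein for displacement of a labelled ligand from metabotropic glutamate receptor 5 (Homo sapiens), with a stated time of 60 min, tested at 1 uM; a lower number here means less inhibition, a higher number more inhibition at the concentration tested (going by the name of the read-out): compound 3 gives 92%, while compound 2 `CC1CCN(c2c(S(=O)(=O)c3ccc(Cl)c(Cl)c3)cnc3cc(F)ccc23)CC1` gives 94%, a gap within the scatter. Compound 1 `Cc1cc(C)cc(S(=O)(=O)c2cnc3cc(F)ccc3c2N2CCC(C)CC2)c1` gives 80%, and a number 12 percentage points higher from compound 1 to compound 3 (beyond the scatter). Compound 4 `CC1CCN(c2c(S(=O)(=O)c3ccc(Cl)cc3)cnc3cc(F)ccc23)CC1` differs from compound 3 in one place: 4-chlorophenyl in place of 3-cyanophenyl on a sulfonyl sulfur. Earlier swaps of the aryl group on the sulfonyl sulfur bear on this: a number 14 percentage points higher from compound 1 to compound 2 (beyond the scatter) and a number 12 percentage points higher from compound 1 to compound 3 (beyond the scatter), both modest, whereas a number 2 percentage points lower from compound 2 to compound 3 (within the scatter), within the scatter. The three measured aryl groups thus sit close together at high inhibition, so a number 2 percentage points lower from compound 3 to compound 4 (within the scatter) is expected to stay within the scatter. Compound 4 is expected to give about 90%, in a range of 80% to 97%.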

Compound 4, a percentage reported as inhibition, at one concentration (the size of the read-out at that concentration, not a potency): 90%
Compound 4: middle estimate and measured number agree at the digits printed; the measured number falls inside the stated range.
By their numbers in this assay, from the lowest: compounds 1, 4, 3 and 2 (each within the scatter of the next, the first and the last beyond it).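

With one chloro on the phenyl ring, inhibition at the sulfonyl sulfur stays level with both the 3-cyanophenyl and the 3,4-dichlorophenyl compounds: a number 2 percentage points lower from compound 3 to compound 4 (within the scatter) and a number 4 percentage points lower from compound 2 to compound 4 (within the scatter), both within the scatter. The new result also blurs the separation from the 3,5-dimethylphenyl group, since a number 10 percentage points higher from compound 1 to compound 4 (within the scatter) stays within the scatter, although compound 2 and compound 3 each clear it against compound 1. Nothing available here explains these steps.

From the compounds shown here alone, whether a phenyl ring carrying an amine or a carboxylic acid would hold this level remains open. Single-concentration values also leave the order among compound 2, compound 3 and compound 4 unresolved.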